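Propyl for Cyclopropyl in a Thiophene Analogue

A few compounds are considered here, and "the series" means these few. Any claim that something is new, unique, unknown or untested is made for them only; others in the source may bear on it.

Measured in an assay on membranes from HeLa cells for displacement of a labelled ligand from adenosine receptor A3 (Homo sapiens), read by scintillation counting, with a stated time of 180 min, tested at 1 uM; a higher number here means more inhibition at the concentration tested (going by the name of the read-out), a lower number less inhibition:
compound 1 `CC1=C(C(=O)C2CC2)C(c2ccco2)NC(=O)N1` gives 7%
compound 2 `CCCC(=O)C1=C(C)NC(=O)NC1c1ccco1` gives 1%
compound 3 `CC1=C(C(=O)C2CC2)C(c2ccsc2)NC(=O)N1` gives 1%

All three sit at low inhibition. The change propyl in place of cyclopropyl on a carbonyl carbon gave a number 6 percentage points lower from compound 1 to compound 2 (within the scatter). The two cores differ by thiophen-3-yl in place of furan-2-yl on a saturated ring carbon, which gave a number 6 percentage points lower from compound 1 to compound 3 (within the scatter). Compound 3 and compound 2 show no change at the digits reported.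

Compound 4 `CCCC(=O)C1=C(C)NC(=O)NC1c1ccsc1` is not yet measured. It differs from compound 3 by propyl in place of cyclopropyl on a carbonyl carbon; the place is described in the same words as for the step from compound 1 to compound 2, so this is the same change. The expected step is a number 1 percentage points lower from compound 3 to compound 4 (within the scatter), which rests on compound 1 and compound 2 showing a number 6 percentage points lower from compound 1 to compound 2 (within the scatter), a step inside the scatter from a low starting point. Compound 4 is therefore expected to give 0%, estimated between -8% and 8%.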

Compound 4, a percentage reported as inhibition, at one concentration (the size of the read-out at that concentration, not a potency): 1%
The estimate for compound 4 lay 1 percentage points below the measured number; the range from low to high includes it.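

Propyl in place of cyclopropyl shows no change at the digits printed from compound 3 to compound 4 (within the scatter) in this assay, and this agrees with the earlier step on the other core: the same change on two cores in this assay, a number 6 percentage points lower (within the scatter) from compound 1 to compound 2 and no change at the digits printed (within the scatter) from compound 3 to compound 4, 6 percentage points apart, within the scatter of two such steps. Thiophen-3-yl in place of furan-2-yl shows no change at the digits printed from compound 2 to compound 4 (within the scatter), and this also agrees with its earlier step: the same change on two cores in this assay, a number 6 percentage points lower (within the scatter) from compound 1 to compound 3 and no change at the digits printed (within the scatter) from compound 2 to compound 4, 6 percentage points apart, within the scatter of two such steps. Among the compounds shown here, all four compounds sit at low inhibition, so the agreement shows only that neither change left the scatter on these two cores, not that either change would carry over in the same way on a compound with a clearly higher number.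

The compounds shown leave open how either change behaves where inhibition is substantial. They also leave open what a longer chain on the carbonyl carbon, or a phenyl ring in place of furan-2-yl, would give in this assay.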